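The source may hold more compounds than are shown below. What is called first, only, known or untested is meant among the compounds shown, and "the series" means these compounds.

For the measured compounds named here, compound 1 `Oc1ccc(-c2cc(-c3ccccc3O)cc(-c3ccccc3O)n2)cc1` is the stronger of the two compounds measured so far. In a functional assay on T47D cells (Homo sapiens) for cytotoxicity, read by CCK-8 assay, with a stated time of 4 days (a higher number here means a weaker inhibitor, a lower number a stronger inhibitor), compound 1 gives 960 nM, the lowest of the two numbers. Going by the values given here, its only measured neighbour is compound 2 `Oc1cccc(-c2cc(-c3ccccc3O)cc(-c3ccccc3O)n2)c1`, which in this assay gives 5760 nM; that change, 3-hydroxyphenyl in place of 4-hydroxyphenyl on an aromatic carbon, brought a 6.0-fold higher number from compound 1 to compound 2 (0.78 log units; beyond the scatter).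

Compound 3 `Oc1ccc(-c2cc(-c3ccccc3O)cc(-c3ccc(O)cc3)n2)cc1` has not yet been measured. It differs from compound 1 in one place: 4-hydroxyphenyl in place of 2-hydroxyphenyl on an aromatic carbon. Among the compounds with values here, the one measured step bears on it only indirectly, since it shows that the 4-hydroxyphenyl group in compound 1 matters, and that swapping it away cost a 6.0-fold higher number from compound 1 to compound 2 (0.78 log units; beyond the scatter); nothing measured tells how a second 4-hydroxyphenyl group in place of a 2-hydroxyphenyl group will act. Given that the 4-hydroxyphenyl group appears favourable in compound 1, the step is expected to be small, at most a modest improvement or nothing beyond the scatter, with a 1.4-fold lower number from compound 1 to compound 3 (0.14 log units; within the scatter). Compound 3 is therefore estimated in this assay at 700 nM, within a range from 250 nM to 2500 nM.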

Compound 3, half-maximal inhibitory concentration: 5350 nM
The estimate for compound 3 lay 7.6-fold (0.88 log units) below the measured number; measured number above the stated range.
By their numbers in this assay, from the lowest: compound 1; then compounds 3 and 2 (each within the scatter of the next).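

The 2-hydroxyphenyl group next to the ring nitrogen proved to matter: replacing it with 4-hydroxyphenyl gave a 5.6-fold higher number from compound 1 to compound 3 (0.75 log units; beyond the scatter) in this assay and thus lost most of the strength of compound 1. The two groups have the same counted atoms, donors and acceptors, so this loss goes with the arrangement of the same atoms alone, and a second 4-hydroxyphenyl group did not repeat any benefit suggested by the first. Together with the earlier step, this means that both changes tried on compound 1, one at each of two aryl positions, gave numbers beyond the scatter in the weaker direction. Nothing available explains why the arrangement in compound 1 is preferred here.

On these data alone, it remains open whether the hydroxyl of the 2-hydroxyphenyl group is itself needed at this place, which an unsubstituted phenyl, a methoxy group or an amine in its stead would test. The compounds shown also leave open how 3-hydroxyphenyl would act at this place, and whether the remaining 2-hydroxyphenyl group of compound 1 is as sensitive to change.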